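The compounds below may be only part of what the source reports. "The series", "measured", "known", "first", "only" and "open" are said of these compounds alone.

Measured so far:
- compound 1, `Cn1cc(-c2cnc3ccc(N)nc3c2)cn1`: > 50000 nM, a limit of the assay
- compound 2, `COc1ccc(C(=O)Nc2ccc3ncc(-c4cnn(C)c4)cc3n2)cc1`: 6400 nM

In a functional assay on A549 cells (Homo sapiens) for antiproliferative activity, read by MTT assay, with a stated time of 48 h (a higher number here means a weaker inhibitor, a lower number a stronger inhibitor), compound 1 gives > 50000 nM, which is a limit of the assay and not a number. Compound 1 sits at the limit of > 50000 nM in this assay, at which 1 of the 2 values shown sits. In this assay compound 2 gives 6400 nM. Within the data shown here, compound 2 therefore holds the only number seen in this assay so far; there is no measured pair from which a size of step can be read.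

Compound 3, `Cn1cc(-c2cnc3ccc(NC(=O)c4cccnc4)nc3c2)cn1`, differs from compound 2 by pyridin-3-yl in place of 4-methoxyphenyl on a carbonyl carbon whose other neighbour is an amide-type nitrogen. The amide and the shared core stay as in compound 2. Among the measured compounds shown here, with no measured step to lean on, the expected step in this assay is a 1.4-fold higher number from compound 2 to compound 3 (0.15 log units; within the scatter), a mild weakening that may well stay within the usual scatter. Compound 3 is estimated at 9000 nM, with a range from 2500 nM to 30000 nM.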

Compound 3, half-maximal inhibitory concentration: > 50000 nM
Compound 3: a limit, no number; the forecaster's own chance of this, stated with the estimate: 15%; at least 5.5-fold (0.74 log units) between middle value and limit.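

On the carbonyl carbon whose other neighbour is the amide-type nitrogen, the acyl group decides whether a number can be read at all in this assay: pyridin-3-yl in place of 4-methoxyphenyl gives an at least 7.8-fold higher number from compound 2 to compound 3 (0.89 log units; beyond the scatter). Compound 3 gives > 50000 nM, which is a limit of the assay and not a number. The amide alone is thus not enough for a measurable value in this pair, and the step between compound 1 and compound 3 cannot be read, since both values are limits: the limit of > 50000 nM in this assay, at which 2 of the 3 values shown sit.

Open, on these data alone, is whether the value of compound 2 goes with the methoxy group or with the ring of carbon only. An unsubstituted phenyl or a 4-chlorophenyl on the same carbonyl would separate the two.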